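The source may hold more compounds than are shown below. What is called first, only, known or untested is meant among the compounds shown, and "the series" means these compounds.

Working notes on the series. Of the compounds shown here, two carry a number so far. Compound 1 `N=C(CS)NCC12CCCC(CCC1)C2` gives 23% in a functional assay on the whole organism (stomach, strain beagle) for inhibition, with Canis familiaris (Canis lupus familiaris) as the target, with a stated time of 2 h, at a dose of 16 mg/kg; on this read-out lower numbers stand for a weaker effect and higher numbers for a stronger effect at the one dose given. Compound 2 `N=C(CS)Nc1ccccc1` gives 0% in this assay. On these two numbers compound 2 stands lowest; its nearest neighbour, compound 1, lies higher by a margin beyond the scatter. Within the data shown here, the two compounds differ from each other in more than one place, so no single step joins them; all that can be said is what their two values show.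

Compound 3 `N=C(CS)Nc1cccc(Cl)c1` is not yet measured. It differs from compound 2 in one place: chloro in place of hydrogen on an aromatic carbon, on an aromatic carbon of a six-membered aromatic ring of carbon only, meta to a group of 5 heavy atoms.

Among the measured compounds shown here, no step between measured compounds informs this change, and compound 2 rests at the bottom of the read-out, so the number can only rise or stay flat. The step of a number 8 percentage points higher from compound 2 to compound 3 (within the scatter) is expected to be small, upward if at all, and probably within the scatter. For compound 3 the estimate in this assay is 8%, with a range from 0% to 28%.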

Compound 3, a percentage reported as inhibition, in the whole organism at one dose (the size of the read-out at that dose, not a potency): 16%
Estimate against measurement, compound 3: 8 percentage points below, within the range that was stated.
By their numbers in this assay, from the lowest: compound 2; then compounds 3 and 1 (each within the scatter of the next).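

In this assay, among these compounds, chloro in place of hydrogen on an aromatic carbon gives a number 16 percentage points higher from compound 2 to compound 3 (beyond the scatter) as the first change that can be read in one place. It shows that this aromatic carbon, meta to a group of 5 heavy atoms, is not indifferent to what it carries: a single chlorine atom lifts the read-out clear of the bottom value of compound 2, though only by a modest step. The step comes from a single dose and gives the size of the effect at that dose, not a potency, and nothing measured here bears on its origin.

The compounds shown leave open whether the step belongs to chlorine itself or would also appear with another group at this place, such as fluoro, bromo, methyl, methoxy, trifluoromethyl, an amine or a carboxylic acid. They also leave open how chloro behaves on the other aromatic carbons of the ring, and whether a second chloro would add to the step or leave the read-out unchanged.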